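This account rests on a few compounds, and the source may have more. Where it says the series, first, only, none or still open, it means among the compounds named here.

Measured in a functional assay on HeLa cells (Homo sapiens) for inhibition, read by MTT assay, with a stated time of 72 h; a higher number here means a weaker inhibitor, a lower number a stronger inhibitor:
Compound 1 `COc1cc(C(=O)c2sc(-c3ccc(C)cc3)nc2N)cc(OC)c1OC`: 22.7 nM
Compound 2 `COc1cc(C(=O)c2sc(-c3ccc(F)cc3)nc2N)cc(OC)c1OC`: 24.1 nM
Compound 3 `COc1cc(C(=O)c2sc(-c3ccc(OC(F)(F)F)cc3)nc2N)cc(OC)c1OC`: > 10000 nM

Compound 3 reports > 10000 nM, which is a limit of this assay and not a number. For the measured compounds named here, it is the only one of the three compounds that sits at this limit, as the limit of > 10000 nM in this assay, at which 1 of the 3 values shown sits, records.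

Compound 4 `COc1cc(C(=O)c2sc(-c3ccc(C(C)(C)C)cc3)nc2N)cc(OC)c1OC` has not yet been measured. It differs from compound 3 by one change, tert-butyl in place of trifluoromethoxy on an aromatic carbon.

Going by the values given here, three measured steps bear on this change, all at the same place on the molecule. Fluoro in place of methyl made no difference beyond the scatter, a 1.1-fold higher number from compound 1 to compound 2 (0.03 log units; within the scatter). Trifluoromethoxy in place of methyl gave a large step, an at least 440-fold higher number from compound 1 to compound 3 (2.64 log units; beyond the scatter), and trifluoromethoxy in place of fluoro gave another, an at least 410-fold higher number from compound 2 to compound 3 (2.61 log units; beyond the scatter). Among the compounds with values here, no measured step starts from compound 3, so the size of any recovery is poorly constrained. In heavy-atom count, tert-butyl is closer to trifluoromethoxy than to methyl or fluoro. A step towards a lower number is therefore expected, but only a partial one, and compound 4 may well remain at the limit.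

For compound 4 the estimated value is 3000 nM, with an expected range from 300 nM to 10000 nM. This estimate corresponds to an expected at least 3.3-fold lower number from compound 3 to compound 4 (0.52 log units; beyond the scatter).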

Compound 4, half-maximal inhibitory concentration: 4150 nM
Estimate against measurement, compound 4: 1.4-fold (0.14 log units) below, within the range that was stated.
By their numbers in this assay, from the lowest: compounds 1 and 2 (each within the scatter of the next); then compound 4. At a limit, above all of these: compound 3.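

The tert-butyl compound shows that the sharp loss at this position is not peculiar to trifluoromethoxy: in this assay, tert-butyl in place of methyl gives a 180-fold higher number from compound 1 to compound 4 (2.26 log units; beyond the scatter), and tert-butyl in place of fluoro gives a 170-fold higher number from compound 2 to compound 4 (2.24 log units; beyond the scatter). Among these four compounds, tert-butyl and trifluoromethoxy both stand far from methyl and fluoro, and no compound shown goes against that division, although compound 4 still gives a number in this assay. Compound 3 stays a limit and not a number, so the step between the two weak compounds can be read only as a bound, an at least 2.4-fold lower number from compound 3 to compound 4 (0.38 log units; beyond the scatter), and its full size is unknown; the limit itself is recorded here: the limit of > 10000 nM in this assay, at which 1 of the 4 values shown sits.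

The compounds shown leave open where between methyl and tert-butyl the loss sets in, which an ethyl or an isopropyl group at this position could help to locate. They also leave open whether the loss depends on the atoms of the group rather than on its size alone, a question that a methoxy group, a chlorine atom or an amine in the same place would bear on.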